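The source may hold more compounds than are shown below. What is called first, only, known or untested is meant among the compounds shown, and "the series" means these compounds.

Measured in a functional assay on MT4 cells (Homo sapiens) for cytotoxicity; on this read-out lower numbers stand for stronger inhibition and higher numbers for weaker inhibition:
Compound 1 `N#Cc1ccc([S+]([O-])c2cccc(N)c2C#N)cc1`: > 200000 nM, a limit of the assay.
Compound 2 `CCOc1cc(C)cc(S(=O)(=O)c2cccc(N)c2C#N)c1`: 9000 nM.

For the measured compounds named here, compound 2 carries the only actual number in this small set, as the reading for compound 1 is a limit. Compound 3 `COc1cc(C)cc(S(=O)(=O)c2cccc(N)c2C#N)c1` has not yet been measured. It differs from compound 2 by hydrogen in place of methyl on a saturated chain carbon bound to an oxygen on an aromatic ring, which is hydrogen in place of methyl on a saturated chain carbon bound to an oxygen on an aromatic ring, or ethoxy to methoxy. Going by the values given here, no measured step covers this change, so only a modest shift towards weaker inhibition in this assay is expected, little beyond the scatter. The expected change is a 1.6-fold higher number from compound 2 to compound 3 (0.19 log units; within the scatter). Compound 3 is estimated at 14000 nM, with an expected range of 6000 nM to 50000 nM.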

Compound 3, half-maximal inhibitory concentration: 94000 nM
For compound 3 the middle estimate is 6.7-fold (0.83 log units) below the measured one; measured number above the stated range.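

In this assay, the change from ethoxy to methoxy gives a 10-fold higher number from compound 2 to compound 3 (1.02 log units; beyond the scatter), so this single carbon on the chain bound to an oxygen on an aromatic ring matters well beyond the scatter. For the compounds shown here, no earlier pair could show this, as compound 1 and compound 2 differ in more than one place. Compound 1 offers only a limit, not a number: the limit of > 200000 nM in this assay, at which 1 of the 3 values shown sits.

This one step covers ethoxy and methoxy alone. As far as these compounds go, how a longer chain such as propoxy, or a hydroxyl or an amine at this place, would read remains open.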